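Swapping the carbonyl group: compound 3 to compound 4

A few compounds are considered here, and "the series" means these few. Any claim that something is new, unique, unknown or untested is made for them only; others in the source may bear on it.

Measured so far in an in vivo ADME assay on the whole organism for pharmacokinetics, with Rattus norvegicus as the target; on this read-out lower numbers stand for slow clearance and higher numbers for fast clearance:
- compound 1 `CCCS(=O)(=O)N1CCC(CNC(=O)C2CC2)(C(=O)N2CCOCC2)CC1`: 18 mL/min/kg
- compound 2 `CCCS(=O)(=O)N1CCC(CNC(=O)c2ccc(F)cc2C(F)(F)F)(C(=O)N2CCOCC2)CC1`: 18 mL/min/kg
- compound 3 `CCCS(=O)(=O)N1CCC(CNC(=O)c2c(F)ccc(Cl)c2F)(C(=O)N2CCOCC2)CC1`: 18 mL/min/kg

Compound 3 stands at 18 mL/min/kg, level with compounds 1 and 2 in this assay. The next compound, compound 4 `CCCS(=O)(=O)N1CCC(CNC(=O)c2ccccc2Cl)(C(=O)N2CCOCC2)CC1`, keeps the shared core and alters only the group on the carbonyl carbon: 2-chlorophenyl in place of 3-chloro-2,6-difluorophenyl on a carbonyl carbon. In words, this places 2-chlorophenyl in place of 3-chloro-2,6-difluorophenyl on a carbonyl carbon.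

Among the measured compounds shown here, three measured steps bear on this change, as each exchanges the group at that same place. They read no change at the digits printed from compound 1 to compound 2 (within the scatter), no change at the digits printed from compound 1 to compound 3 (within the scatter) and no change at the digits printed from compound 2 to compound 3 (within the scatter). None of these exchanges moved the read-out, whether the group was cyclopropyl or one of the two substituted phenyl groups. For the measured compounds named here, no measured compound carries 2-chlorophenyl, and three compounds give a narrow basis, so the expectation is a carry-over from these steps and not an established rule.

No step beyond the scatter is expected, in either direction. The expected step is no change at the digits printed from compound 3 to compound 4 (within the scatter). For compound 4 the estimated value is 18 mL/min/kg, with an expected range of 12 mL/min/kg to 27 mL/min/kg.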

Compound 4, clearance: 18 mL/min/kg
Compound 4: middle estimate and measured number agree at the digits printed; measured number inside the range.
By their numbers in this assay, from the lowest: compounds 1, 2, 3 and 4 (each within the scatter of the next).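

Working notes on the group on the carbonyl carbon: in this assay, the series now holds a phenyl group with chlorine as its only halogen, and the read-out shows no change at the digits printed from compound 3 to compound 4 (within the scatter), no change at the digits printed from compound 2 to compound 4 (within the scatter) and no change at the digits printed from compound 1 to compound 4 (within the scatter). Both earlier substituted phenyl groups carried fluorine, so these steps add something new: across the four compounds, clearance at this place does not depend on fluorine being present, and the exchange of 3-chloro-2,6-difluorophenyl (9 heavy atoms) for 2-chlorophenyl (7 heavy atoms) leaves the read-out where it stood. The data on hand offer no explanation for this insensitivity.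

On these data alone, all four groups are a cyclopropyl ring or a halogen-bearing phenyl ring, so it remains open whether a group carrying an amine or a carboxylic acid, or a longer alkyl chain in place of cyclopropyl, on this carbonyl carbon would still leave clearance unmoved. The rest of the shared core is the same in all four compounds, so these results say nothing about how clearance responds to a change anywhere else in the molecule.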